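A few compounds are considered here, and "the series" means these few. Any claim that something is new, unique, unknown or untested is made for them only; others in the source may bear on it.

Three compounds on the shared core have numbers in an in vivo ADME assay on the whole organism (strain 129/SvEvBrd x C57BL/6) for pharmacokinetics, with Mus musculus as the target; a lower number here means that a smaller share of the oral dose reaches the circulation, a higher number that a larger share of the oral dose reaches the circulation. Compound 2 (`Cc1nc(-c2nc([C@@H](O)[C@H](O)[C@H](O)CO)c[nH]2)cs1`) stands at 23%, within the scatter of compound 1 (`OC[C@@H](O)[C@@H](O)[C@H](O)c1c[nH]c(C(F)(F)C(F)(F)F)n1`) at 31%. Compound 3 (`OC[C@@H](O)[C@@H](O)[C@H](O)c1c[nH]c(-c2ncn(Cc3ccccc3)n2)n1`) gives 6%, lower than compound 2 by a margin beyond the scatter.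

Compound 4 (`OC[C@@H](O)[C@@H](O)[C@H](O)c1c[nH]c(-c2ncon2)n1`) has not been measured yet. It carries 1,2,4-oxadiazol-3-yl in place of 2-methyl-1,3-thiazol-4-yl on an aromatic carbon.

Within the data shown here, no two measured compounds differ in one place only, so no measured step speaks directly to this change. The expectation rests on compound 2 at 23% and compound 1 at 31%, which lie within the scatter of each other. The range stays wide on the low side, given compound 3 at 6%. No step beyond the scatter is expected in this assay, in either direction. The estimated step is a number 2 percentage points higher from compound 2 to compound 4 (within the scatter), and it is expected to stay within the scatter. For compound 4 the expected value is 25%, with an estimated range from 10% to 42%.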

Compound 4, oral bioavailability: 5%
Estimate against measurement, compound 4: 20 percentage points above, outside the stated range (below it).
By their numbers in this assay, from the lowest: compounds 4 and 3 (each within the scatter of the next); then compounds 2 and 1 (each within the scatter of the next).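

In this assay, among these compounds, the change from 2-methyl-1,3-thiazol-4-yl to 1,2,4-oxadiazol-3-yl gives the one readable step, a number 18 percentage points lower from compound 2 to compound 4 (beyond the scatter), so the two five-membered aromatic rings are not interchangeable at this position, on the aromatic carbon between two ring nitrogen atoms. The groups differ only modestly in what can be counted: the leaving group has 6 heavy atoms and 2 hydrogen-bond acceptors, the entering group 5 heavy atoms and 3 hydrogen-bond acceptors, and neither has a hydrogen-bond donor or a net charge. Nothing available shows which difference between the two groups, whether the sulfur, the methyl group or the added ring nitrogen, accounts for the step.

Still open, going by these compounds, is whether a simple 1,3-thiazol-4-yl without the methyl group, or a 1,3,4-oxadiazol-2-yl, would stay with compound 2 or fall with compound 4, which would help separate the contribution of the ring from that of its substituent. Also open is how this position responds to a primary amine or a carboxylic acid, neither of which appears among the compounds shown.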